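A few compounds are considered here, and "the series" means these few. Any claim that something is new, unique, unknown or untested is made for them only; others in the source may bear on it.

Values in an ADME assay on J774 cells (Mus musculus) for cytotoxicity, read by MTT assay, with a stated time of 48 h; a lower number here means a stronger inhibitor, a higher number a weaker inhibitor
compound 1 `NCCCCNc1cc(/C=C/c2ccccc2)nc2ccccc12` gives 6600 nM
compound 2 `CCN(CC)CC(=O)NCCNc1cc(/C=C/c2ccccc2)nc2ccccc12` gives 700 nM
compound 3 `O=C(CN1CCCC1)NCCNc1cc(/C=C/c2ccccc2)nc2ccccc12` gives 12500 nM
compound 4 `Nc1cc(/C=C/c2ccccc2)nc2ccccc12` is not yet measured

Compound 1 stands within the scatter of compound 3 and well apart from compound 2. The steps are (a 1.9-fold higher number from compound 1 to compound 3 (0.28 log units; within the scatter)) and (a 9.4-fold lower number from compound 1 to compound 2 (0.97 log units; beyond the scatter)). The change to compound 4 puts hydrogen in place of 4-aminobutyl on a nitrogen on an aromatic ring. Going by the values given here, no measured step removes the chain outright, so the guide is indirect. Changes further out on the chain already span a large range (an 18-fold higher number from compound 2 to compound 3 (1.25 log units; beyond the scatter)). A step toward a higher number is expected, with low confidence (a 2.3-fold higher number from compound 1 to compound 4 (0.36 log units; beyond the scatter)). Compound 4 is estimated at 15000 nM with an expected range from 4000 nM to 50000 nM in this series.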

Compound 4, half-maximal inhibitory concentration: 4400 nM
For compound 4 the middle estimate is 3.4-fold (0.53 log units) above the measured one, and the stated range covers the measured number.
By their numbers in this assay, from the lowest: compound 2; then compounds 4, 1 and 3 (each within the scatter of the next, the first and the last beyond it).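

In this assay hydrogen in place of 4-aminobutyl on a nitrogen on an aromatic ring stays within the scatter (a 1.5-fold lower number from compound 1 to compound 4 (0.18 log units; within the scatter)). At this position, the whole chain can therefore go without a readable shift, so the number for compound 1 does not depend on the chain being present. No measured evidence bears on the reason for this result.

Still open, going by these compounds, is how a shorter chain, or a carboxylic acid in place of the terminal amine on the butyl chain, would read on this nitrogen.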